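The source may report more compounds than this note shows. Statements on the series, on what has been measured and on what is new or still open speak of the compounds shown alone.

Cytotoxicity read-out, measured compounds in an ADME assay on MT2 cells (Homo sapiens) for cytotoxicity; on this read-out lower numbers stand for higher toxicity in this test and higher numbers for lower toxicity in this test:
compound 1 `CC1(C)OC(=O)C2(C(=O)O1)[C@@H](c1ccco1)CC(=O)C[C@H]2c1c[nH]c2ccccc12`; compound 1 reaches only the assay limit > 111000 nM.
compound 2 `COc1ccc([C@@H]2CC(=O)C[C@H](c3ccco3)C23C(=O)OC(C)(C)OC3=O)cc1`; compound 2 reaches only the assay limit > 111000 nM.
compound 3 `COc1ccc([C@@H]2CC(=O)C[C@H](c3ccco3)C23C(=O)OC(C)(C)OC3=O)cc1OC`; compound 3 reaches only the assay limit > 111000 nM.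

Compound 3 thus stands where every value shown stands: at a limit, not at a number (the limit of > 111000 nM in this assay, at which 3 of the 3 values shown sit). For the measured compounds named here, no step among the measured compounds can be sized. The steps a step that the two limits leave unreadable from compound 1 to compound 2, a step that the two limits leave unreadable from compound 1 to compound 3 and a step that the two limits leave unreadable from compound 2 to compound 3 all run between two limits and remain unreadable.

Compound 4 `COc1cccc([C@@H]2CC(=O)C[C@H](c3ccco3)C23C(=O)OC(C)(C)OC3=O)c1OC` is not yet measured. It differs from compound 3 by 2,3-dimethoxyphenyl in place of 3,4-dimethoxyphenyl on a saturated ring carbon. Going by the values given here, the steps that bear on this change are the exchange of the aromatic group on the saturated ring carbon, from compound 1 to compound 2 and from compound 1 to compound 3, and the methoxy step from compound 2 to compound 3; none of them gave a readable size, and every aromatic group tried so far left the value at the limit. No step beyond the scatter is therefore expected in this assay; the expected step from compound 3 is a step that the limit leaves unreadable from compound 3 to compound 4. Compound 4 is estimated at 150000 nM, with a range from 60000 nM to 400000 nM, and is most likely to be reported again only as a limit.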

Compound 4, half-maximal cytotoxic concentration: > 111000 nM
Compound 4: no number, only a limit; the forecaster's own chance of this, stated with the estimate: 90%; the middle value is on the limit's open side.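

The steps to compound 4 from compound 1, compound 2 and compound 3 cannot be read in this assay, as all four compounds give only a limit: the limit of > 111000 nM in this assay, at which 4 of the 4 values shown sit. The compounds shown leave open where any of the four actual values lies, and whether exchanging the aromatic group on the saturated ring carbon changes the read-out at all.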